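Bromophenyl in place of nitrophenyl on the shared core

The compounds below may be only part of what the source reports. "The series", "measured", "known", "first", "only" and "open" are said of these compounds alone.

Two compounds of the series have numbers in a functional assay on WM 266-4 cells (Homo sapiens) for antiproliferative activity, read by MTT assay, with a stated time of 48 h; a lower number here means a stronger inhibitor of growth, a higher number a weaker inhibitor of growth. Compound 1 `Cc1ccc(C2=NN(C(=S)Nc3ccccc3)C(c3ccc4c(c3)OCCO4)C2)cc1` gives 10300 nM. Going by the values given here, compound 2 `O=[N+]([O-])c1ccc(C2=NN(C(=S)Nc3ccccc3)C(c3ccc4c(c3)OCCO4)C2)cc1` gives 105000 nM and so stands highest of the two numbers, the single measured step of a 10-fold higher number from compound 1 to compound 2 (1.01 log units; beyond the scatter) setting it apart from compound 1.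

Compound 3 `S=C(Nc1ccccc1)N1N=C(c2ccccc2Br)CC1c1ccc2c(c1)OCCO2` is not yet measured. It differs from compound 2 by 2-bromophenyl in place of 4-nitrophenyl on a carbon with a double bond to nitrogen. Among the compounds with values here, only the step from compound 1 to compound 2 bears on this change, and only in part: it shows that the 4-nitrophenyl group goes with the higher number, but no measured compound carries a 2-bromophenyl group at this place, so the direction is taken from the loss of the nitro group alone. The number for compound 3 is expected to fall, with a 5.3-fold lower number from compound 2 to compound 3 (0.72 log units; beyond the scatter) estimated as a step back toward compound 1, smaller than the full measured step. Compound 3 is expected at 20000 nM, in the range 5000 nM to 80000 nM.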

Compound 3, concentration for 50% growth inhibition: > 200000 nM
Compound 3: no number, only a limit; the forecaster's own chance of this, stated with the estimate: 10%; at least 10-fold (1.00 log units) between middle value and limit.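

Compound 3 gives > 200000 nM in this assay and this is a limit of the assay, not a number. At this carbon with a double bond to nitrogen, 2-bromophenyl in place of 4-methylphenyl gives an at least 19-fold higher number from compound 1 to compound 3 (1.28 log units; beyond the scatter) and so shows that removing the nitro group does not by itself bring back growth inhibition. Against 4-nitrophenyl the record is an at least 1.9-fold higher number from compound 2 to compound 3 (0.27 log units; that floor lies within the scatter) and this leaves 2-bromophenyl and 4-nitrophenyl without an order.

The compounds shown do not separate the bromine itself from its ring position, a question that a 4-bromophenyl or a 2-methylphenyl group at this carbon would address. Also open, as far as these compounds go, is how a plain phenyl or a 4-aminophenyl group would read here, relative to the 4-methylphenyl group of compound 1.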